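From Cyclopentyl to Benzyl on the Amide Nitrogen

This account rests on a few compounds, and the source may have more. Where it says the series, first, only, none or still open, it means among the compounds named here.

Of the compounds shown here, two have been measured so far. Compound 1 `COc1cc2c(cc1OC)C(CC(N)=O)CC2` gives 24.6% in a functional assay on the whole organism (strain Swiss albino) for inhibition, with Mus musculus as the target, in the writhing test, with stated times of 60 min and 15 min, at a dose of 100 mg/kg by the oral route (on this read-out higher numbers stand for more inhibition at the one dose given (going by the name of the read-out) and lower numbers for less inhibition), and compound 2 `COc1cc2c(cc1OC)C(CC(=O)NC1CCCC1)CC2` gives 37% in this assay, the higher of the two numbers. Within the data shown here, the only step known is a number 12.4 percentage points higher from compound 1 to compound 2 (beyond the scatter), which shows that a substituent on the amide nitrogen raised the read-out beyond the scatter. The unmeasured compound 3 `COc1cc2c(cc1OC)C(CC(=O)NCc1ccccc1)CC2` keeps the amide nitrogen substituted and differs from compound 2 by benzyl in place of cyclopentyl on an amide-type nitrogen. No measured step compares two different substituents on that nitrogen, so the step from compound 1 to compound 2 bears on compound 3 only in showing that substitution there helps; it gives no reason to expect benzyl to differ much from cyclopentyl. The expected step is therefore a number 1 percentage points higher from compound 2 to compound 3 (within the scatter), within the scatter. Compound 3 is estimated at 38% in this assay, between 25% and 52%.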

Compound 3, a percentage reported as inhibition, in the whole organism at one dose (the size of the read-out at that dose, not a potency): 48.1%
For compound 3 the middle estimate is 10.1 percentage points below the measured one; the range from low to high includes it.
By their numbers in this assay, from the lowest: compound 1; then compound 2; then compound 3.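

The identity of the group on the amide-type nitrogen matters in this assay, which the earlier pair could not show: a number 11.1 percentage points higher from compound 2 to compound 3 (beyond the scatter) separates two ring-bearing substituents and means that benzyl and cyclopentyl are not interchangeable at this position. Among the three groups seen there, benzyl also gives the largest gain over hydrogen, with a number 23.5 percentage points higher from compound 1 to compound 3 (beyond the scatter) for this change, while the swap from cyclopentyl to benzyl alters both ring type and heavy-atom count, and this single step cannot tell those differences apart. Nothing given here accounts for the rise in the read-out.

Still open, on these data alone, is whether a longer chain, as in phenethyl, would keep this gain. As far as these compounds go, it is equally open how a benzyl group carrying chlorine or methoxy would fare on that nitrogen.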